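Replacing the 4-chlorophenyl group of compound 3

The source may hold more compounds than are shown below. What is called first, only, known or untested is meant among the compounds shown, and "the series" means these compounds.

Among the measured compounds shown here, in a functional assay on PC-3 cells (Homo sapiens) (a higher number here means a weaker inhibitor of growth, a lower number a stronger inhibitor of growth), compound 3 `O=S(=O)(/C=C/c1ccc(Cl)cc1)Cc1ccc(Nc2ncnc3ccc(Br)cc23)cc1` gives 2000 nM, the lowest number of the three measured so far. Compound 2 `O=S(=O)(/C=C/c1ccc(Br)cc1)Cc1ccc(Nc2ncnc3ccc(Br)cc23)cc1` gives 34000 nM, and compound 1 `O=S(=O)(/C=C/c1ccc(Cl)cc1)Cc1ccc(Nc2ncnc3ccccc23)cc1` gives 43000 nM. The next compound to be measured, compound 4 `O=S(=O)(/C=C/c1ccc(C(F)(F)F)cc1F)Cc1ccc(Nc2ncnc3ccc(Br)cc23)cc1`, has 2-fluoro-4-(trifluoromethyl)phenyl in place of 4-chlorophenyl on a double-bonded chain carbon bound to a double-bonded chain carbon.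

The closest evidence is a 17-fold lower number from compound 2 to compound 3 (1.23 log units; beyond the scatter), a large step that comes from exchanging only bromo for chloro in the group now being replaced. The other measured step, a 22-fold lower number from compound 1 to compound 3 (1.33 log units; beyond the scatter), is also large, but it comes from a bromo added elsewhere, so it shows only how large steps can be in this small set. Neither fluoro nor trifluoromethyl appears in any measured compound, so the data do not fix the direction. For the measured compounds named here, compound 3 holds the lowest number, and the one other change at this group raised the number, so a higher number is expected in this assay, probably beyond the scatter. The expected step is a 4.0-fold higher number from compound 3 to compound 4 (0.60 log units; beyond the scatter). The estimate for compound 4 is 8000 nM, with an expected range of 1500 nM to 40000 nM.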

Compound 4, concentration for 50% growth inhibition: 58000 nM
Compound 4: the middle estimate sits 7.3-fold (0.86 log units) below what was measured; measured number above the stated range.
By their numbers in this assay, from the lowest: compound 3; then compounds 2, 1 and 4 (each within the scatter of the next).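

In this assay, 2-fluoro-4-(trifluoromethyl)phenyl in place of 4-chlorophenyl gives a 29-fold higher number from compound 3 to compound 4 (1.46 log units; beyond the scatter) and so shows that a second replacement of this group, on a double-bonded chain carbon bound to a double-bonded chain carbon, also raises the number by a large step. Against the 4-bromophenyl group, the same new group gives a 1.7-fold higher number from compound 2 to compound 4 (0.23 log units; within the scatter) and stays within the scatter, so among compounds 2, 3 and 4, which differ only in this group, compound 3 alone has the low number, and both replacements of its 4-chlorophenyl group lose it to a similar extent. Nothing measured on these compounds bears on the reason for this difference.

The compounds shown do not separate the fluoro from the trifluoromethyl in the entering group, so it stays open which of the two accounts for the step, or whether both are needed. Also open, as far as these compounds go, is how an unsubstituted phenyl, a 4-fluorophenyl or a 4-methoxyphenyl group would read at this place, and so whether the low number of compound 3 is particular to chloro.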